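The source may hold more compounds than are shown below. What is called first, only, known or untested is meant among the compounds shown, and "the series" means these compounds.

Measured so far in a functional assay on ileum for inhibition of histamine H1 receptor (Cavia porcellus); a higher number here means a weaker inhibitor, a lower number a stronger inhibitor:
compound 1 `CN1CCN(c2nc3ccccc3[nH]2)CC1`: > 3000 nM
compound 2 `CCCCCN1CCCN(c2nc3ccccc3n2CCOCC)CC1`: 7.4 nM
compound 3 `C=CCOCCn1c(N2CCCN(C)CC2)nc2ccccc21`: 10 nM

The value for compound 1 is a limit of the assay, not a number: the limit of > 3000 nM in this assay, at which 1 of the 3 values shown sits. Compounds 2 and 3 sit far inside the measurable range of this assay. Compound 4 `CCSCCCn1c(N2CCN(C)CC2)nc2ccccc21` is still to be measured; it differs from compound 1 by 3-(ethylsulfanyl)propyl in place of hydrogen on an aromatic nitrogen. For the measured compounds named here, no matched step between two measured compounds is available, so the size of this change cannot be read from a pair. Still, compound 1 at its limit against compounds 2 and 3, each carrying a substituent on an aromatic nitrogen of the shared core, suggests a large move toward a stronger inhibitor, well beyond the scatter. Compound 4 is expected at 20 nM, between 5 nM and 100 nM. The expected step is an at least 150-fold lower number from compound 1 to compound 4 (2.17 log units; beyond the scatter).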

Compound 4, half-maximal inhibitory concentration: 530 nM
Estimate against measurement, compound 4: 27-fold (1.42 log units) below, outside the stated range (above it).
By their numbers in this assay, from the lowest: compounds 2 and 3 (each within the scatter of the next); then compound 4. At a limit, above all of these: compound 1.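

In this assay, for the compounds shown here, 3-(ethylsulfanyl)propyl in place of hydrogen on an aromatic nitrogen of the shared core gives an at least 5.6-fold lower number from compound 1 to compound 4 (0.75 log units; beyond the scatter), the first matched step at this position. The step shows that this one change is enough to bring a measurable number, beyond the scatter. Its full size stays unknown because the value of compound 1 is a limit and not a number: the limit of > 3000 nM in this assay, at which 1 of the 4 values shown sits.

Open, from the compounds shown here alone, is how much the sulfur and the chain length contribute. An ether oxygen in place of the sulfur, or a longer chain on this nitrogen, would separate the two.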